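Propylsulfanyl for ethoxy: expected cytotoxicity of compound 4

The compounds below may be only part of what the source reports. "The series", "measured", "known", "first", "only" and "open" are said of these compounds alone.

The measured compounds, with their values in an ADME assay on CCRF-HSB-2 cells (Homo sapiens) for cytotoxicity, with a stated time of 7 days; on this read-out higher numbers stand for lower toxicity in this test and lower numbers for higher toxicity in this test:
compound 1 `CNc1nc(N)nc2c1ncn2/C=C1/CC1(CO)CO`, which gives the limit > 20000 nM;
compound 2 `CC(C)CSc1nc(N)nc2c1ncn2/C=C1/CC1(CO)CO`, which gives 60000 nM;
compound 3 `CCOc1nc(N)nc2c1ncn2/C=C1/CC1(CO)CO`, which gives the limit > 20000 nM.

Compound 3 stands only at a limit of this assay, not at a number. The same holds for compound 1, as the limit of > 20000 nM in this assay, at which 2 of the 3 values shown sit, shows. Within the data shown here, compound 2 is the one compound with a read number, and it sits far from the toxic end.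

Compound 4 `CCCSc1nc(N)nc2c1ncn2/C=C1/CC1(CO)CO` differs from compound 3 by propylsulfanyl in place of ethoxy on an aromatic carbon. Among the measured compounds shown here, the steps that bear on this change are a step that the limit leaves unreadable from compound 2 to compound 3 and a step that the two limits leave unreadable from compound 1 to compound 3; both are left unreadable by the limits, and a step that the limit leaves unreadable from compound 1 to compound 2 is unreadable too. For the measured compounds named here, nothing among the three therefore shows a change beyond the scatter, and the only number, from compound 2 with its isobutylsulfanyl group, points to low toxicity for a sulfur-linked chain.

Compound 4 is thus expected to show a step that the limit leaves unreadable from compound 3 to compound 4, no readable step. Compound 4 is estimated at 50000 nM, within 20000 nM to 150000 nM.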

Compound 4, half-maximal cytotoxic concentration: 98000 nM
The estimate for compound 4 lay 2.0-fold (0.29 log units) below the measured number; the measured number falls inside the stated range.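

In this assay, the loss of one methyl from the chain gives a 1.6-fold higher number from compound 2 to compound 4 (0.21 log units; within the scatter), so isobutylsulfanyl and propylsulfanyl cannot be told apart at this position. Among these compounds, this position now carries two sulfur-linked chains with read numbers, where the earlier compounds offered only one, and the branch on that chain makes no difference beyond the scatter. The steps that involve compound 1 or compound 3 cannot be read, as these two compounds stand only at a limit of the assay: the limit of > 20000 nM in this assay, at which 2 of the 4 values shown sit.

On these data alone, how far propylsulfanyl really differs from ethoxy or methylamino stays open: neither the oxygen-linked nor the nitrogen-linked compound has a read number. Also open, as far as these compounds go, is how a longer chain on the sulfur, such as pentylsulfanyl, or a benzylsulfanyl group would read at this position.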